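Halogen swap on the pyridinyl arm: bromo to chloro

The source may hold more compounds than are shown below. What is called first, only, known or untested is meant among the compounds shown, and "the series" means these compounds.

Compound 1 `O=C(CCCCCc1ccccc1)c1nc2cccnc2o1` gives 1700 nM in an assay on HEK-293T cells for inhibition of diacylglycerol lipase-alpha (Homo sapiens), read by colorimetric assay; a higher number here means a weaker inhibitor, a lower number a stronger inhibitor. Compound 2 `O=C(CCCCCCc1ccccc1)c1ncno1` reaches only the limit of > 10000 nM there; this is a limit of the assay, not a number (the limit of > 10000 nM in this assay, at which 1 of the 3 values shown sits). Compound 3 `O=C(CCCCCCc1ccccc1)c1nc(-c2cccc(Br)n2)no1` gives 2040 nM, the highest of the two numbers, with compound 1 nearest and within the scatter. For the measured compounds named here, the one step seen, an at least 4.9-fold lower number from compound 2 to compound 3 (0.69 log units; beyond the scatter), is at least modest. Compound 4 `O=C(CCCCCCc1ccccc1)c1nc(-c2cccc(Cl)n2)no1` differs from compound 3 by chloro in place of bromo on an aromatic carbon. Going by the values given here, no measured step bears on this halogen exchange; the only step concerns adding the whole bromopyridinyl group. The expectation is therefore a change of no more than a 1.0-fold lower number from compound 3 to compound 4 (0.01 log units; within the scatter), within the scatter. Compound 4 is estimated at 2000 nM, in the range 1000 nM to 4500 nM.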

Compound 4, half-maximal inhibitory concentration: > 10000 nM
Compound 4 gave a limit, no number (the forecaster's own chance of this, stated with the estimate: 10%); middle value at least 5.0-fold (0.69 log units) away from the limit.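

Chloro in place of bromo on this aromatic carbon, next to the ring nitrogen, is not a neutral exchange in this assay: it gives an at least 4.9-fold higher number from compound 3 to compound 4 (0.69 log units; beyond the scatter). The activity gained with the 6-bromopyridin-2-yl group therefore depends on the halogen and does not come from the pyridinyl ring alone, while the step from compound 2 to compound 4 cannot be read. The result for compound 4 is a limit of the assay, not a number: the limit of > 10000 nM in this assay, at which 2 of the 4 values shown sit.

On these data alone, what iodo, methyl or an amine would do at this carbon stays open. So does the real size of the loss with chloro.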